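The source may report more compounds than this note shows. Statements on the series, on what has been measured and on what is new or still open speak of the compounds shown alone.

The measured compounds and their values:

Compound 1, `COc1cc(-c2nccn3cc(-c4ccc(C(F)(F)F)cc4)nc23)cc(OC)c1OC`, in a functional assay on HCT-116 cells (Homo sapiens) for inhibition, read by MTT assay, with a stated time of 48 h (on this read-out lower numbers stand for stronger inhibition and higher numbers for weaker inhibition), gives > 10000 nM; this is a limit of the assay, not a number.
Compound 2, `COc1cc(-c2nccn3cc(-c4ccc(N)cc4)nc23)cc(OC)c1OC`, in this assay gives 158 nM.
Compound 3, `COc1cc(-c2nccn3cc(-c4ccccc4)nc23)cc(OC)c1OC`, in this assay gives 266 nM.

Compound 3 carries a plain phenyl ring and holds the higher of the two numbers, but its nearest neighbour, compound 2, sits close by: a 1.7-fold higher number from compound 2 to compound 3 (0.23 log units; within the scatter). Compound 1 stands apart, with only a limit reported, as noted in the limit of > 10000 nM in this assay, at which 1 of the 3 values shown sits.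

The compound still to be measured, compound 4, `COc1cc(-c2nccn3cc(-c4ccc(C)cc4)nc23)cc(OC)c1OC`, differs from compound 3 by methyl in place of hydrogen on an aromatic carbon. Within the data shown here, two measured steps touch the same aromatic carbon. Swapping trifluoromethyl for hydrogen gave an at least 37-fold lower number from compound 1 to compound 3 (1.57 log units; beyond the scatter), and swapping amino for hydrogen gave a 1.7-fold higher number from compound 2 to compound 3 (0.23 log units; within the scatter). So the groups tried at this position range from one that pushes the value beyond the measurable limit to two whose numbers lie within the scatter of one another. Methyl has not been tried, and no measured step tells how a small carbon group behaves here. The expectation is therefore a modest step toward a higher number, possibly within the scatter: a 1.5-fold higher number from compound 3 to compound 4 (0.18 log units; within the scatter). Compound 4 is estimated at 400 nM, with a likely range from 150 nM to 1500 nM.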

Compound 4, half-maximal inhibitory concentration: 74 nM
The estimate for compound 4 lay 5.4-fold (0.73 log units) above the measured number; the measured number lies below the stated range.
By their numbers in this assay, from the lowest: compound 4; then compounds 2 and 3 (each within the scatter of the next). At a limit, above all of these: compound 1.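

In this assay, among these compounds, methyl in place of hydrogen on this aromatic carbon gives the first step among the small groups that clearly exceeds the usual scatter: a 3.6-fold lower number from compound 3 to compound 4 (0.56 log units; beyond the scatter). The earlier compounds shown here could not show this, since amino and hydrogen could not be told apart at this position, whereas methyl can be separated from amino as well, with a 2.1-fold lower number from compound 2 to compound 4 (0.33 log units; beyond the scatter). Methyl in place of trifluoromethyl gives an at least 130-fold lower number from compound 1 to compound 4 (2.13 log units; beyond the scatter), so having a carbon group at this position does not by itself decide the outcome, and the value for compound 1 is a limit, not a number: the limit of > 10000 nM in this assay, at which 1 of the 4 values shown sits.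

The compounds shown leave open whether a longer chain such as ethyl, a methoxy group or a chlorine atom on the same carbon would lower the number further or raise it toward that limit. They also give no reason for the order seen, and with only one cell assay shown, whether the gain from the 4-methylphenyl ring holds in other cells remains an open question.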